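The source may report more compounds than this note shows. Statements on the series, on what has been measured and on what is new or still open speak of the compounds shown alone.

Three compounds of the series share one core and carry a substituted benzylamine on it. Compound 1 `O=[N+]([O-])c1cccc(CNc2cc(Br)cc3[nH]ncc23)c1` gives 72% in an assay for inhibition of Indoleamine 2,3-dioxygenase 1 (Homo sapiens), with stated times of 10 min and 60 min, tested at 10 uM; a higher number here means a stronger effect of the compound at the concentration tested, a lower number a weaker effect. For the measured compounds named here, compound 2 `O=[N+]([O-])c1cccc(CNc2cc(C(F)(F)F)cc3[nH]ncc23)c1` gives 45% in this assay; the single change between the two is told by the step of a number 27 percentage points lower from compound 1 to compound 2 (beyond the scatter). Compound 3 `N#Cc1cc(NCc2ccccc2[N+](=O)[O-])c2cn[nH]c2c1` gives 7% in this assay; it differs from compound 2 in more than one place, so only the two values themselves are set side by side. Compound 2 thus stands second highest of the three numbers, beyond the scatter from compound 1 above it and beyond the scatter from compound 3 below it.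

Compound 4 `FC(F)(F)c1cc(NCc2cccc(Br)c2)c2cn[nH]c2c1` differs from compound 2 by bromo in place of nitro on an aromatic carbon. Going by the values given here, no measured step touches this place: the one step known swaps bromo for trifluoromethyl on the core, not on the pendant ring, and compound 3, which also carries nitro, differs from compound 2 in several ways at once. Among the compounds with values here, there is therefore no step of the same kind to lean on; the known step of a number 27 percentage points lower from compound 1 to compound 2 (beyond the scatter) only sets the scale of changes seen so far, and a step within the scatter is the plain expectation. For compound 4 the expected value in this assay is 40%, within 20% to 60%. The expected step is a number 5 percentage points lower from compound 2 to compound 4 (within the scatter).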

Compound 4, a percentage reported as inhibition, at one concentration (the size of the read-out at that concentration, not a potency): 23%
The estimate for compound 4 lay 17 percentage points above the measured number; measured number inside the range.
By their numbers in this assay, from the lowest: compound 3; then compound 4; then compound 2; then compound 1.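

In this assay, the change on the substituted benzylamine gives a number 22 percentage points lower from compound 2 to compound 4 (beyond the scatter), so this carbon of the six-membered aromatic ring, meta to a large group, is a second place in the series where one substitution moves the read-out beyond the scatter. The earlier step concerned only the shared core, whereas this one shows that, with trifluoromethyl on the core, bromo does not stand in for nitro on the benzyl part without a loss of inhibition at the tested concentration. No measurement given here accounts for this difference between nitro and bromo.

For the compounds shown here, whether the same swap would lower the read-out with bromo on the core, as in compound 1, remains open, since the single pair at this place carries trifluoromethyl on the core and compound 3 differs from the others in more than one place. Also open, as far as these compounds go, is how an amine, a carboxylic acid or a nitrile at this carbon would read against nitro and bromo, which would show whether nitro is unusual here or bromo is.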